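The compounds below may be only part of what the source reports. "The series", "measured", "known", "first", "only" and "open" are said of these compounds alone.

In a functional assay on K562 cells (Homo sapiens) for cytotoxicity, read by MTT assay, with a stated time of 48 h (on this read-out lower numbers stand for stronger inhibition and higher numbers for weaker inhibition), compound 1 `CCCCOC(=O)/C=C/c1ccc2c(c1)C(=O)C(=O)N2Cc1ccc(OC)cc1` gives 40 nM against compound 2 `CC(C)(C)OC(=O)/C=C/c1ccc2c(c1)C(=O)C(=O)N2Cc1ccc(Br)cc1` at 290 nM and compound 3 `CCCCOC(=O)/C=C/c1ccc2c(c1)C(=O)C(=O)N2Cc1ccc(Br)cc1` at 150 nM on the same read-out. Compound 3 is not separated from compound 2 and lies beyond the scatter above compound 1. Compound 4 `CCOC(=O)/C=C/c1ccc2c(c1)C(=O)C(=O)N2Cc1ccc(Br)cc1` brings the change hydrogen in place of ethyl on a saturated chain carbon, two bonds along the chain from an oxygen next to a carbonyl group to compound 3: hydrogen in place of ethyl on a saturated chain carbon, two bonds along the chain from an oxygen next to a carbonyl group, which reads butyl to ethyl. The closest measured change, butyl in place of tert-butyl on an oxygen next to a carbonyl group, is a 1.9-fold lower number from compound 2 to compound 3 (0.29 log units; within the scatter) and stays within the scatter. The bromo in place of methoxy step a 3.8-fold higher number from compound 1 to compound 3 (0.57 log units; beyond the scatter) sits on an aromatic carbon and leaves this chain untouched. No shift beyond the scatter is therefore expected in this assay and the expected size is a 1.2-fold higher number from compound 3 to compound 4 (0.08 log units; within the scatter) by estimate. For compound 4 the estimated value is 180 nM with a range from 70 nM to 450 nM as its upper end.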

Compound 4, half-maximal inhibitory concentration: 30 nM
Beside the measured number, compound 4's estimate is 6.0-fold (0.78 log units) above it, and the stated range ends above it.
By their numbers in this assay, from the lowest: compounds 4 and 1 (each within the scatter of the next); then compounds 3 and 2 (each within the scatter of the next).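

In this assay, this saturated chain on the ester oxygen proves able to move the number beyond the scatter: butyl to ethyl gives (a 5.0-fold lower number from compound 3 to compound 4 (0.70 log units; beyond the scatter)), whereas the earlier tert-butyl to butyl step stayed within it. Ethyl in place of tert-butyl gives (a 9.7-fold lower number from compound 2 to compound 4 (0.99 log units; beyond the scatter)), so with bromo held constant, the two steps that end at ethyl are the ones that lie beyond the scatter. Nothing at hand explains this shift.

Going by these compounds, a propyl chain, a methyl ester or a carboxylic acid remains open here. Also open, on these data alone, is whether ethyl in place of butyl gives a similar step when methoxy replaces bromo, as in compound 1.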